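Adding a methoxy group to compound 2

A few compounds are considered here, and "the series" means these few. Any claim that something is new, unique, unknown or untested is made for them only; others in the source may bear on it.

Compound 1 `COc1cccc2cc(-c3ccccc3)c(O)nc12`: 10000 nM
Compound 2 `COc1ccc2cc(-c3ccccc3)c(O)nc2c1`: 10000 nM

In a functional assay on T47D cells (Homo sapiens) for cytotoxicity, read by colorimetric assay and MTT assay (on this read-out higher numbers stand for weaker inhibition and lower numbers for stronger inhibition), compound 2 stands level with compound 1, with no difference beyond the usual scatter. The next compound, compound 3 `COc1cc(OC)c2cc(-c3ccccc3)c(O)nc2c1`, differs from compound 2 by one change, methoxy in place of hydrogen on an aromatic carbon. Among the measured compounds shown here, no measured pair shows what such a change does in this assay, so no shift beyond the scatter is expected in either direction. The expected change is small: a 1.1-fold lower number from compound 2 to compound 3 (0.05 log units; within the scatter). For compound 3 the estimated value is 9000 nM, with an expected range from 3000 nM to 20000 nM.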

Compound 3, half-maximal inhibitory concentration: 10000 nM
For compound 3 the middle estimate is 1.1-fold (0.05 log units) below the measured one; measured number inside the range.
By their numbers in this assay, from the lowest: compounds 1, 2 and 3 (each within the scatter of the next).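

In this assay, among the compounds shown here, a methoxy group on an aromatic carbon, ortho to a fused ring and meta to a methoxy group, gives no change at the digits printed from compound 2 to compound 3 (within the scatter) and is the first measured step for this change. At this position, then, the methoxy group leaves the number where it stood on the core of compound 2. Nothing given here bears on why the number holds.

The compounds shown leave open whether an amine, a carboxylic acid or a longer alkoxy chain at this position would move the number. They also leave open whether a change to the phenyl group would do so.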